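Ethoxycarbonyl in Place of Cyano, Tested on a Second Core

This account rests on a few compounds, and the source may have more. Where it says the series, first, only, none or still open, it means among the compounds named here.

Compound 1 `Cc1ccc2nc(C)n(-n3c(N)c(C#N)c(-c4ccccc4)c(C#N)c3=O)c(=O)c2c1` was examined in a functional assay on MCF7 cells (Homo sapiens) for cytotoxicity, read by MTT assay, with a stated time of 3 days (a higher number here means a weaker inhibitor, a lower number a stronger inhibitor), where compound 1 gives 8000 nM. Compound 2 `CCOC(=O)c1c(-c2ccccc2)c(C#N)c(=O)n(-n2c(C)nc3ccc(C)cc3c2=O)c1N` differs from compound 1 by ethoxycarbonyl in place of cyano on an aromatic carbon, and in this assay compound 2 gives 17000 nM, so that the change produced a 2.1-fold higher number from compound 1 to compound 2 (0.33 log units; beyond the scatter).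

Compound 3 `Cc1ccc2nc(C)n(NC(=O)c3sc(N)c(C#N)c3N)c(=O)c2c1` carries a different core; the difference between the two cores is not broken down here. In this assay compound 3 gives 10000 nM, a number that lies within the usual scatter of the values of both compound 1 and compound 2.

Compound 4 `CCOC(=O)c1c(N)sc(C(=O)Nn2c(C)nc3ccc(C)cc3c2=O)c1N` is the unmeasured partner of compound 3 and differs from it by ethoxycarbonyl in place of cyano on an aromatic carbon. This is the same kind of change as that from compound 1 to compound 2, but the surroundings differ: in compound 2 the group sits on an aromatic carbon of a six-membered aromatic ring with 1 nitrogen, ortho to a phenyl group and ortho to an amino group, whereas in compound 4 it sits on an aromatic carbon of a five-membered aromatic ring with 1 sulfur, next to two ring atoms that each bear an amino group.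

Within the data shown here, because the only precedent is a 2.1-fold higher number from compound 1 to compound 2 (0.33 log units; beyond the scatter), a step of similar size is expected here, a 1.8-fold higher number from compound 3 to compound 4 (0.26 log units; within the scatter), with added uncertainty from the different core. Compound 4 is therefore estimated at 18000 nM in this assay, expected to fall between 8000 nM and 40000 nM.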

Compound 4, half-maximal inhibitory concentration: 16000 nM
Compound 4: the middle estimate sits 1.1-fold (0.05 log units) above what was measured, and the stated range covers the measured number.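

Exchanging cyano for ethoxycarbonyl on the core of compound 3 gives a 1.6-fold higher number from compound 3 to compound 4 (0.20 log units; within the scatter) in this assay, so this step, taken alone, cannot be told apart from the variation between repeated measurements. Set beside the earlier step, it gives no sign that the outcome of this change depends on the core, and both steps point the same way, although only the first lies beyond the scatter: the same change on two cores in this assay, a 2.1-fold higher number (0.33 log units; beyond the scatter) from compound 1 to compound 2 and a 1.6-fold higher number (0.20 log units; within the scatter) from compound 3 to compound 4, 1.3-fold (0.12 log units) apart, within the scatter of two such steps. Among these compounds, this agreement rests on just two matched pairs, so it shows only that the two steps cannot be separated in this one cell assay; it does not show that the change has a real effect on the second core, that the step would have the same size on any other core, or what lies behind the step on either core.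

The compounds shown carry only cyano or ethoxycarbonyl at this place, which leaves open how a carboxylic acid, a carboxamide or a longer ester chain would read in this assay on either core. From the compounds shown here alone, it also remains open whether the step would hold on the core of compound 3 if an amino group on the ring were exchanged for a methyl group.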